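This account rests on a few compounds, and the source may have more. Where it says the series, first, only, none or still open, it means among the compounds named here.

Compound 3 `CC(C(=O)NCc1ccc(C(C)(C)C)cc1N1CCCCC1)c1ccc(NS(C)(=O)=O)c(F)c1` sits at 1.9 nM in an assay on cells for antagonist activity at transient receptor potential cation channel subfamily V member 1 (Homo sapiens), read by FLIPR and calcium flux, with a stated time of 6 min (a higher number here means a weaker inhibitor, a lower number a stronger inhibitor), the second highest of the three numbers recorded. It is close to compound 1 `CCCCCCSc1nc(C(C)(C)C)ccc1CNC(=O)C(C)c1ccc(NS(C)(=O)=O)c(F)c1`, which gives 1.5 nM, a gap within the usual scatter, and far from compound 2 `CC(C(=O)NCc1ccc(C(C)(C)C)nc1SCCCN(C)C)c1ccc(NS(C)(=O)=O)c(F)c1`, which gives 51.8 nM. Within the data shown here, the single measured step, a 35-fold higher number from compound 1 to compound 2 (1.54 log units; beyond the scatter), is a large loss of potency, but it concerns a different change on the chain and does not bear directly on the present question.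

Compound 4 `CCCCSc1cc(C(C)(C)C)ccc1CNC(=O)C(C)c1ccc(NS(C)(=O)=O)c(F)c1` differs from compound 3 in one place: butylsulfanyl in place of piperidin-1-yl on an aromatic carbon. Among the measured compounds shown here, no measured step matches this change. For the measured compounds named here, the only guide is that compound 1, which also carries an alkylsulfanyl chain on its core, gives 1.5 nM, a number close to that of compound 3. Compound 4 is therefore expected to stay near compound 3, with a step of a 1.2-fold higher number from compound 3 to compound 4 (0.06 log units; within the scatter) that lies within the scatter. The estimate for compound 4 is 2.2 nM, with a range from 0.7 nM to 7 nM.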

Compound 4, inhibition constant: 6.7 nM
Compound 4: the middle estimate sits 3.0-fold (0.48 log units) below what was measured; low and high end bracket the measured number.
By their numbers in this assay, from the lowest: compounds 1 and 3 (each within the scatter of the next); then compound 4; then compound 2.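

In this assay, putting butylsulfanyl in place of piperidin-1-yl on this aromatic carbon, ortho to a large group and meta to a tert-butyl group, gives a 3.5-fold higher number from compound 3 to compound 4 (0.55 log units; beyond the scatter), so the position is sensitive to which of these two groups it carries, though the step is modest. The change swaps a ring for an open chain and a nitrogen for a sulfur at the same time, so this single step cannot show which of the two differences matters. Nothing measured here gives a reason for the difference.

Going by these compounds, it remains open how a butylamino chain, which keeps the open chain but links through nitrogen, would compare with these two groups at this position. A morpholine ring or a longer chain, such as hexylamino, would also test how much this position tolerates.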